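Methoxy on the aryl ring of indolinone-thiazolone pyrazolines

A few compounds are considered here, and "the series" means these few. Any claim that something is new, unique, unknown or untested is made for them only; others in the source may bear on it.

The measured compounds and their values:

Compound 1, `COc1ccc(C2CC(c3ccccc3)=NN2C2=NC(=O)/C(=C3\C(=O)Nc4ccc(Br)cc43)S2)cc1`: 210 nM
Compound 2, `COc1ccc(C2=NN(C3=NC(=O)/C(=C4\C(=O)Nc5ccc(Br)cc54)S3)C(c3ccc(OC)cc3)C2)cc1`: 190 nM
Compound 3, `O=C1N=C(N2N=C(c3ccccc3)CC2c2ccc(Cl)cc2)S/C1=C1/C(=O)Nc2ccccc21`: 280 nM

Of the compounds shown here, three have been measured in a functional assay on cells (Melanoma cell, Homo sapiens) for cytotoxicity, read by sulforhodamine B assay, with a stated time of 48 h; on this read-out lower numbers stand for stronger inhibition of growth and higher numbers for weaker inhibition of growth. Compound 1 gives 210 nM. Compound 2 carries one further group, (methoxy in place of hydrogen on an aromatic carbon), and in this assay compound 2 gives 190 nM; the step is a 1.1-fold lower number from compound 1 to compound 2 (0.04 log units; within the scatter). Compound 3, in this assay, gives 280 nM; its values against compound 1 and compound 2 lie within the usual scatter, so no order among the three can be drawn. The difference between the core of compound 3 and the core of compound 1 is not broken down here.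

Compound 4, `COc1ccc(C2=NN(C3=NC(=O)/C(=C4\C(=O)Nc5ccccc54)S3)C(c3ccc(Cl)cc3)C2)cc1`, has not yet been measured. It differs from compound 3 by methoxy in place of hydrogen on an aromatic carbon, the same change as that from compound 1 to compound 2, made at the same kind of place. Because that earlier step was a 1.1-fold lower number from compound 1 to compound 2 (0.04 log units; within the scatter), the step from compound 3 to compound 4 is expected to be small as well, estimated as a 1.1-fold lower number from compound 3 to compound 4 (0.05 log units; within the scatter). On this basis compound 4 is expected to give about 250 nM in this assay, with the estimate most likely falling between 120 nM and 520 nM.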

Compound 4, concentration for 50% growth inhibition: 100000 nM
Beside the measured number, compound 4's estimate is 400-fold (2.60 log units) below it; measured number outside the range, above it.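

In this assay, the change from phenyl to 4-methoxyphenyl did not carry over from one core to the other, and the two steps clearly differ: the same change on two cores in this assay, a 1.1-fold lower number (0.04 log units; within the scatter) from compound 1 to compound 2 and a 360-fold higher number (2.55 log units; beyond the scatter) from compound 3 to compound 4, 390-fold (2.60 log units) apart, beyond the scatter of two such steps

On the core of compound 3 the change is large, with a 360-fold higher number from compound 3 to compound 4 (2.55 log units; beyond the scatter), whereas on the core of compound 1 the same change gives a 1.1-fold lower number from compound 1 to compound 2 (0.04 log units; within the scatter), so a step that makes no readable difference on one core in this series cannot be taken as a guide to the same step on another. The result does not show why the two cores respond differently: they differ in more than one place, with a bromo group on the core of compound 1 and a chloro group in compound 3 and compound 4 where compound 1 and compound 2 have methoxy, and two pairs cannot separate these differences or support a rule for other cores.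

The compounds shown leave open whether the bromo group or the chloro group decides how the methoxy change behaves, which a pair differing only in one of these groups could settle. They also leave open whether a smaller or larger group in the same place, such as fluoro, hydroxy or ethoxy, would give a step like that from compound 3 to compound 4 on this core.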